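The compounds below may be only part of what the source reports. "The series", "measured", "known", "first", "only" and "open" are said of these compounds alone.

Compound 1 `COc1ccc(-c2nn3c(NC4CCCC4)cccc3c2-c2ccnc(NC3CCCC3)n2)cc1` carries a 4-methoxyphenyl on the shared core. In an ADME assay on Vero cells (Chlorocebus sabaeus) for cytotoxicity (a higher number here means that more compound is tolerated, a lower number that less compound is tolerated), compound 1 gives only a limit, > 100000 nM, so no number is known for it. This value sits at the limit of > 100000 nM in this assay, at which 1 of the 3 values shown sits. Compound 2 `c1ccc(-c2nn3c(NC4CCCC4)ccnc3c2-c2ccnc(NC3CCCC3)c2)cc1` has a different core and a phenyl in place of the 4-methoxyphenyl; in this assay compound 2 gives 14000 nM. Compound 3 `c1ccc(-c2nn3c(NC4CCCC4)ncnc3c2-c2ccnc(NC3CCCC3)n2)cc1` has yet another core and also a phenyl; in this assay compound 3 gives only a limit, > 40000 nM, which is the limit of > 40000 nM in this assay, at which 1 of the 3 values shown sits. Going by the values given here, no two of these three differ in a single place, so no step of one change has been measured here.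

Compound 4 `c1ccc(-c2nn3c(NC4CCCC4)cccc3c2-c2ccnc(NC3CCCC3)n2)cc1` has not yet been run in this assay. From compound 1 to compound 4 the change is hydrogen in place of methoxy on an aromatic carbon. Among the compounds with values here, with only a limit for compound 1 and no measured step of this kind, no direction beyond the scatter is expected. Compound 4 is expected to give about 60000 nM, in the range 20000 nM to 200000 nM, an expected step of an at least 1.6-fold lower number from compound 1 to compound 4 (0.22 log units; that floor lies within the scatter).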

Compound 4, half-maximal cytotoxic concentration: > 40000 nM
Compound 4 was reported as a limit (the forecaster's own chance of this, stated with the estimate: 50%); the middle value lies beyond the limit too.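

In this assay, compound 1 and compound 4 are both reported only as limits, so the step from hydrogen in place of methoxy cannot be read. The compounds shown leave open whether going from 4-methoxyphenyl to phenyl changes the tolerated concentration at all.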